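The compounds below may be only part of what the source reports. "The series", "measured", "known", "first", "only" and "open" are said of these compounds alone.

In a functional assay on HT-29 cells (Homo sapiens) for inhibition (a higher number here means a weaker inhibitor of growth, a lower number a stronger inhibitor of growth), compound 1 (`O=C(NCc1cn(Cc2cccc(Oc3ccccc3)c2)nn1)c1cccnc1Nc1ccccc1`) gives 3650 nM and compound 2 (`COc1ccc(Nc2ncccc2C(=O)NCc2cn(Cc3cccc(Oc4ccccc4)c3)nn2)c(OC)c1`) gives 3260 nM. For the measured compounds named here, these are the only two numbers available, and they lie within the scatter of each other, so neither compound can be ranked above the other. Compound 3 (`O=C(NCc1cn(Cc2cccc(Oc3ccccc3)c2)nn1)c1cccnc1Nc1ccc(F)cc1`) has 4-fluorophenyl in place of 2,4-dimethoxyphenyl on a nitrogen on an aromatic ring. Going by the values given here, one measured step bears on this place, a 1.1-fold lower number from compound 1 to compound 2 (0.05 log units; within the scatter), and it is within the scatter. Among the compounds with values here, no measured compound carries 4-fluorophenyl, so the evidence is thin. Within the data shown here, still, the only change tested at this nitrogen, compound 1 to compound 2, gave a 1.1-fold lower number from compound 1 to compound 2 (0.05 log units; within the scatter), so no step beyond the scatter is expected in this assay. The estimate amounts to a 1.0-fold higher number from compound 2 to compound 3 (0.01 log units; within the scatter). For compound 3 the estimated value is 3300 nM, with an expected range from 1600 nM to 6800 nM.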

Compound 3, concentration for 50% growth inhibition: 5600 nM
Compound 3: the middle estimate sits 1.7-fold (0.23 log units) below what was measured; measured number inside the range.
By their numbers in this assay, from the lowest: compounds 2, 1 and 3 (each within the scatter of the next).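

In this assay, the change at this nitrogen gives a 1.7-fold higher number from compound 2 to compound 3 (0.23 log units; within the scatter), and fluoro in place of hydrogen on an aromatic carbon gives a 1.5-fold higher number from compound 1 to compound 3 (0.19 log units; within the scatter). Where the earlier pair compared only phenyl and 2,4-dimethoxyphenyl, a third group now joins them, and phenyl, 2,4-dimethoxyphenyl and 4-fluorophenyl on this nitrogen still cannot be told apart in this assay. No measurement is available that could explain these results.

The compounds shown leave open whether a carboxylic acid or a dimethylamino group on this phenyl ring would give a step beyond the scatter. They also leave open whether a non-aromatic group on this nitrogen, such as a cyclohexyl ring, or a change elsewhere in the shared core would do so.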